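Lengthening a Short Chain: What One Carbon Does

The source may report more compounds than this note shows. Statements on the series, on what has been measured and on what is new or still open speak of the compounds shown alone.

Compound 1, `CCCCCCCCCCn1cc(-c2nc3ccccc3cc2C)nn1`, gives 44.5 ug/mL in a functional assay on COLO 205 cells (Homo sapiens) for cytotoxicity, read by MTT assay, with a stated time of 24 h; a higher number here means a weaker inhibitor, a lower number a stronger inhibitor.
Compound 2, `CCCCCCCCCCn1cc(-c2nc3ccccc3cc2CC)nn1`, gives > 100 ug/mL in this assay, a limit of the assay rather than a number.
Compound 3, `CCc1cc2ccccc2nc1-c1cn(-c2ccc(F)cc2)nn1`, gives > 100 ug/mL in this assay, again a limit.

Compound 1 and compound 2 differ by methyl in place of hydrogen on a saturated chain carbon bound to an aromatic carbon. The step is an at least 2.2-fold higher number from compound 1 to compound 2 (0.35 log units; beyond the scatter), and it runs into (the limit of > 100 ug/mL in this assay, at which 2 of the 3 values shown sit). Compound 4, `CCCc1cc2ccccc2nc1-c1cn(-c2ccc(F)cc2)nn1`, has not been measured; it differs from compound 3 by methyl in place of hydrogen on a saturated chain carbon, two bonds along the chain from an aromatic carbon. This is the same kind of change, but the place differs: on a saturated chain carbon bound to an aromatic carbon in compound 2, and on a saturated chain carbon, two bonds along the chain from an aromatic carbon in compound 4. The difference between the two cores is not broken down here. Compound 3 already sits at a limit in this assay. Compound 4 is therefore expected to stay there, an expected step that the limit leaves unreadable from compound 3 to compound 4. Compound 4 is estimated at 150 ug/mL, most likely between 80 ug/mL and 400 ug/mL.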

Compound 4, half-maximal inhibitory concentration: > 100 ug/mL
Compound 4: only a limit was reported; the forecaster's own chance of this, stated with the estimate: 85%; the middle value is on the limit's open side.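

No step can be read from compound 3 to compound 4, as both results are limits rather than numbers: the limit of > 100 ug/mL in this assay, at which 3 of the 4 values shown sit.

The compounds shown leave open whether the change from ethyl to propyl alters the result at all in this assay.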